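Bromophenyl in Place of Isopropylphenyl: An Expected Weaker Number

This account rests on a few compounds, and the source may have more. Where it says the series, first, only, none or still open, it means among the compounds named here.

In a functional assay on PC-3 cells (Homo sapiens) for antiproliferative activity, read by MTT assay, with a stated time of 72 h (on this read-out higher numbers stand for weaker inhibition and lower numbers for stronger inhibition), compound 3 `CC(C)c1ccc(/C=C/C(=O)c2ccc(OCC(=O)N[C@H]3CCOC3=O)cc2)cc1` gives 4660 nM, the lowest of the three numbers measured. Compound 2 `CC(C)(C)c1ccc(/C=C/C(=O)c2ccc(OCC(=O)N[C@H]3CCOC3=O)cc2)cc1` gives 10600 nM and compound 1 `O=C(COc1ccc(C(=O)/C=C/c2ccc(F)c(F)c2)cc1)N[C@H]1CCOC1=O` gives 21900 nM; the steps of a 2.3-fold lower number from compound 2 to compound 3 (0.36 log units; beyond the scatter) and a 4.7-fold lower number from compound 1 to compound 3 (0.67 log units; beyond the scatter) are both beyond the scatter, as is a 2.1-fold lower number from compound 1 to compound 2 (0.32 log units; beyond the scatter). Compound 4 `O=C(COc1ccc(C(=O)/C=C/c2cccc(Br)c2)cc1)N[C@H]1CCOC1=O` differs from compound 3 by 3-bromophenyl in place of 4-isopropylphenyl on a double-bonded chain carbon bound to a double-bonded chain carbon. The change from compound 1 to compound 3 bears most directly on this move, since it also exchanged a halogen-bearing phenyl for the isopropylphenyl, and it ran toward stronger inhibition in a 4.7-fold lower number from compound 1 to compound 3 (0.67 log units; beyond the scatter). Returning to a halogen-bearing phenyl in compound 4 is therefore expected to move the number upward, by roughly a 2.6-fold higher number from compound 3 to compound 4 (0.41 log units; beyond the scatter). Compound 4 is thus estimated at 12000 nM, with a range from 4000 nM to 36000 nM.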

Compound 4, half-maximal inhibitory concentration: 7890 nM
The estimate for compound 4 lay 1.5-fold (0.18 log units) above the measured number; the measured number falls inside the stated range.
By their numbers in this assay, from the lowest: compounds 3, 4 and 2 (each within the scatter of the next, the first and the last beyond it); then compound 1.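

With 3-bromophenyl on a double-bonded chain carbon bound to a double-bonded chain carbon, a halogen-bearing phenyl proved compatible with numbers level with those of the 4-isopropylphenyl and 4-(tert-butyl)phenyl compounds (a 1.7-fold higher number from compound 3 to compound 4 (0.23 log units; within the scatter); a 1.3-fold lower number from compound 2 to compound 4 (0.13 log units; within the scatter)). It also separated from 3,4-difluorophenyl (a 2.8-fold lower number from compound 1 to compound 4 (0.44 log units; beyond the scatter)), so halogen-bearing phenyls at this position do not share a single level. No evidence is available to explain these steps. The compounds shown leave open how 4-bromophenyl would compare with 3-bromophenyl, and whether a phenyl bearing an amine or a carboxylic acid would hold this level.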